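Primary amine at the chain terminus of the dioxane series

A few compounds are considered here, and "the series" means these few. Any claim that something is new, unique, unknown or untested is made for them only; others in the source may bear on it.

Measured so far in an assay for displacement of a labelled ligand from Sigma non-opioid intracellular receptor 1 (Cavia porcellus), read by scintillation counting; on this read-out higher numbers stand for weaker inhibition and lower numbers for stronger inhibition:
Compound 1 `CNCC[C@@H]1CCOC(c2ccccc2)(c2ccccc2)O1` gives > 10000 nM, which is a limit of this assay.
Compound 2 `CN(C)CC[C@@H]1CCOC(c2ccccc2)(c2ccccc2)O1` gives 660 nM.
Compound 3 `c1ccc(CNCC[C@@H]2CCOC(c3ccccc3)(c3ccccc3)O2)cc1` gives 320 nM.

Compound 3 holds the lowest number of the two measured values; compound 2 sits a modest step higher, a 2.1-fold lower number from compound 2 to compound 3 (0.31 log units; beyond the scatter). Compound 1 reaches only the limit (the limit of > 10000 nM in this assay, at which 1 of the 3 values shown sits).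

Compound 4 `NCCC[C@@H]1CCOC(c2ccccc2)(c2ccccc2)O1` is the next member: aminomethyl in place of benzylamino on a saturated chain carbon, two bonds along the chain from a saturated ring carbon. Among the measured compounds shown here, two measured steps bear on it. Both run the opposite way, from the unsubstituted amine of compound 1 outward: an at least 15-fold lower number from compound 1 to compound 2 (1.18 log units; beyond the scatter) and an at least 31-fold lower number from compound 1 to compound 3 (1.49 log units; beyond the scatter). Each was large, and each added carbon on the amine nitrogen or on the chain carbon bound to it. Compound 4 strips the benzyl away altogether, leaving a chain carbon carrying a bare amine, a smaller substitution than in compound 1. A large step upward in this assay is therefore expected, a 63-fold higher number from compound 3 to compound 4 (1.80 log units; beyond the scatter), most likely ending at the limit as compound 1 did.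

Compound 4 is estimated at 20000 nM, with a range from 5000 nM to 100000 nM.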

Compound 4, inhibition constant: 175 nM
For compound 4 the middle estimate is 110-fold (2.06 log units) above the measured one; the measured number lies below the stated range.
By their numbers in this assay, from the lowest: compounds 4 and 3 (each within the scatter of the next); then compound 2. At a limit, above all of these: compound 1.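

In this assay, benzylamino gives way to aminomethyl on a saturated chain carbon, two bonds along the chain from a saturated ring carbon, with a 1.8-fold lower number from compound 3 to compound 4 (0.26 log units; within the scatter), so compound 3 and compound 4 cannot be ordered and the benzyl ring brings no gain that can be read here. Against dimethylamino the same group gives a 3.8-fold lower number from compound 2 to compound 4 (0.58 log units; beyond the scatter), which shows that carbon substituents on the nitrogen are not required for a reading in this range. Against methylamino the step is an at least 57-fold lower number from compound 1 to compound 4 (1.75 log units; beyond the scatter), so the weak end of the series does not extend to every small amine, and compound 1 reads only as a limit: the limit of > 10000 nM in this assay, at which 1 of the 4 values shown sits.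

The compounds shown do not separate the effect of the longer chain from that of the free amine, and a dimethylamino or benzylamino group carried on the 2-aminoethyl chain of compound 4 would bear directly on that. Also open, going by these compounds, is how far the trend runs with a still longer chain ending in a primary amine, or with a piperidine at the chain end.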